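Swapping trifluoromethoxy for trifluoromethyl on the sulfonyl aryl ring

A few compounds are considered here, and "the series" means these few. Any claim that something is new, unique, unknown or untested is made for them only; others in the source may bear on it.

Three analogues sharing one core were tested in a functional assay on HeLa cells (Homo sapiens) for cytotoxicity, read by MTT assay, with a stated time of 48 h; on this read-out higher numbers stand for weaker inhibition and lower numbers for stronger inhibition. Compound 1 `CCN(CC)c1ccc2cc(C(=O)c3ccc(N4CCN(C(=O)CN5CCN(C(=O)/C=C/c6ccccc6)CC5)CC4)cc3)oc2c1` gives 5260 nM. Compound 2 `CCN(CC)c1ccc2cc(C(=O)c3ccc(N4CCN(C(=O)CN5CCN(S(=O)(=O)C6CC6)CC5)CC4)cc3)oc2c1` gives 28100 nM, and compound 3 `CCN(CC)c1ccc2cc(C(=O)c3ccc(N4CCN(C(=O)CN5CCN(S(=O)(=O)c6ccc(OC(F)(F)F)cc6)CC5)CC4)cc3)oc2c1` gives 30200 nM, the highest of the three numbers, though the gap to compound 2 lies within the scatter. Compound 4 `CCN(CC)c1ccc2cc(C(=O)c3ccc(N4CCN(C(=O)CN5CCN(S(=O)(=O)c6ccc(C(F)(F)F)cc6)CC5)CC4)cc3)oc2c1` differs from compound 3 by trifluoromethyl in place of trifluoromethoxy on an aromatic carbon. Among the compounds with values here, no measured step alters this group directly; the nearest, a 1.1-fold higher number from compound 2 to compound 3 (0.03 log units; within the scatter), reshaped the sulfonyl substituent far more and still stayed within the scatter, whereas a 5.3-fold higher number from compound 1 to compound 2 (0.73 log units; beyond the scatter) concerned a different part. Compound 4 is therefore expected to sit close to compound 3 in this assay, with a step of a 1.0-fold lower number from compound 3 to compound 4 (0.00 log units; within the scatter), and its estimated value is 30000 nM, within 12000 nM to 75000 nM.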

Compound 4, half-maximal inhibitory concentration: > 40000 nM
Compound 4: a limit, no number; the forecaster's own chance of this, stated with the estimate: 10%; middle value at least 1.3-fold (0.12 log units) from the limit.
By their numbers in this assay, from the lowest: compound 1; then compounds 2 and 3 (each within the scatter of the next). At a limit, above all of these: compound 4.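

In this assay compound 4 gives > 40000 nM, which is a limit and not a number. Trifluoromethyl in place of trifluoromethoxy gives an at least 1.3-fold higher number from compound 3 to compound 4 (0.12 log units; that floor lies within the scatter), and 4-(trifluoromethyl)phenyl in place of cyclopropyl gives an at least 1.4-fold higher number from compound 2 to compound 4 (0.15 log units; that floor lies within the scatter); both floors lie within the scatter, so neither step shows a real change, though neither rules one out. What is new is that the group on this aromatic carbon, para to a large group, has been varied directly, and the change brought no lower number. As far as these compounds go, the true value of compound 4 stays open. So does whether an amine or a carboxylic acid on this carbon would give a lower number.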